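The compounds below may be only part of what the source reports. "The series", "measured", "known", "first", "only" and "open" are said of these compounds alone.

Measured compounds in a physicochemical assay for solubility, in phosphate buffer, with a stated time of 18 h, at pH 7; on this read-out lower numbers stand for lower solubility and higher numbers for higher solubility:
compound 1 `CC(=O)N1CCCC([C@@H]2[C@@H](C(=O)Nc3ccc(F)c(C#N)c3)c3ccccc3C(=O)N2CC(C)C)C1`, 69000 nM
compound 2 `CC(C)CN1C(=O)c2ccccc2[C@H](C(=O)Nc2ccc(F)c(C#N)c2)[C@H]1c1ccsc1`, < 1000 nM
compound 3 `CC(C)CN1C(=O)c2ccccc2[C@H](C(=O)Nc2ccc(F)c(C#N)c2)[C@H]1c1ccoc1`, 15000 nM

Compound 1 stands highest of the two numbers shown, with compound 3 nearest: a 4.6-fold lower number from compound 1 to compound 3 (0.66 log units; beyond the scatter). The value of compound 2 is a limit of this assay and not a number, (the limit of < 1000 nM in this assay, at which 1 of the 3 values shown sits).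

The unmeasured compound 4 `CC(C)CN1C(=O)c2ccccc2[C@H](C(=O)Nc2ccc(F)c(C#N)c2)[C@H]1c1ccnnc1` arises from compound 1 by pyridazin-4-yl in place of 1-acetylpiperidin-3-yl on a saturated ring carbon. The measured steps that bear on this are the two earlier exchanges of the same 1-acetylpiperidin-3-yl group for an aromatic ring on the saturated ring carbon: an at least 69-fold lower number from compound 1 to compound 2 (1.83 log units; beyond the scatter) and a 4.6-fold lower number from compound 1 to compound 3 (0.66 log units; beyond the scatter). Between those two aromatic rings, an at least 15-fold higher number from compound 2 to compound 3 (1.17 log units; beyond the scatter). Both exchanges lowered the number, one large and one modest, and no six-membered aromatic ring with 2 hetero atoms has yet been measured at this position in the series, so the size remains uncertain. A decrease beyond the scatter is expected, closer to the furan-3-yl case than to the thiophen-3-yl case; for compound 4 the expected step is a 2.8-fold lower number from compound 1 to compound 4 (0.44 log units; beyond the scatter). The estimate for compound 4 in this assay is 25000 nM, with a range from 6000 nM to 90000 nM.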

Compound 4, solubility: 28000 nM
Beside the measured number, compound 4's estimate is 1.1-fold (0.05 log units) below it, and the stated range covers the measured number.
By their numbers in this assay, from the lowest: compounds 3 and 4 (each within the scatter of the next); then compound 1. At a limit, below all of these: compound 2.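

In this assay, pyridazin-4-yl on the saturated ring carbon again gives a lower number than 1-acetylpiperidin-3-yl, a 2.5-fold lower number from compound 1 to compound 4 (0.39 log units; beyond the scatter), so all three aromatic rings shown at this position go the same way against compound 1. The six-membered aromatic ring cannot be told apart from the five-membered furan-3-yl, a 1.9-fold higher number from compound 3 to compound 4 (0.27 log units; within the scatter), while thiophen-3-yl stays well apart from it, an at least 28-fold higher number from compound 2 to compound 4 (1.44 log units; beyond the scatter), which leaves thiophen-3-yl as the one clear outlier among the aromatic rings. The value of compound 2 is a limit and not a number: the limit of < 1000 nM in this assay, at which 1 of the 4 values shown sits.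

The compounds shown leave open how much of the step away from compound 1 belongs to the acetyl group and how much to the saturated ring itself, a question that a piperidin-3-yl with a free secondary amine at the same carbon would address. Also open, from the compounds shown here alone, is whether the hetero atoms of the six-membered aromatic ring matter at all, which a plain phenyl or a pyridin-4-yl ring at this position would show.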